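The compounds below may be only part of what the source reports. "The series", "measured", "known", "first", "only" and "open" are said of these compounds alone.

Of the compounds shown here, two of one shared core have been measured in an assay on membranes from CHO cells for displacement of a labelled ligand from adenosine receptor A1 (Homo sapiens), read by scintillation counting, with a stated time of 60 min, tested at 1 uM; on this read-out higher numbers stand for more inhibition at the one concentration tested (going by the name of the read-out) and lower numbers for less inhibition. Compound 1 `CC1=C(C(=O)CC(C)C)C(c2ccsc2)NC(=O)N1` gives 37% in that assay. Compound 2 `CC1=C(C(N)=O)C(c2ccsc2)NC(=O)N1` gives 2%, the lowest of the two numbers; its nearest neighbour is compound 1, reached by a number 35 percentage points lower from compound 1 to compound 2 (beyond the scatter), a step that exchanged an isobutyl on a carbonyl carbon for an amino group. Compound 3 `CC1=C(C(=O)NC(C)C)C(c2ccsc2)NC(=O)N1` has not yet been measured. It differs from compound 2 in one place: isopropyl in place of hydrogen on an amide-type nitrogen. Among the compounds with values here, the only measured step that bears on this change is the one from compound 1 to compound 2, which removed a branched alkyl chain from the carbonyl and was large; compound 3 puts a branched alkyl chain back, though on the nitrogen rather than on the carbonyl carbon, so a return toward the value of compound 1 is plausible but far from certain. Compound 3 is therefore expected to show a moderate rise, a number 13 percentage points higher from compound 2 to compound 3 (beyond the scatter), in this assay. The estimate for compound 3 is 15%, with a range from 0% to 40%.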

Compound 3, a percentage reported as inhibition, at one concentration (the size of the read-out at that concentration, not a potency): 8%
Beside the measured number, compound 3's estimate is 7 percentage points above it; the measured number falls inside the stated range.
By their numbers in this assay, from the lowest: compounds 2 and 3 (each within the scatter of the next); then compound 1.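

In this assay, the step of isopropyl in place of hydrogen on the amide-type nitrogen is a number 6 percentage points higher from compound 2 to compound 3 (within the scatter), so at this position the read-out does not tell the isopropyl group from the amide hydrogen. The isopropylamino group also fails to stand in for the isobutyl on the carbonyl carbon, as the step between those two groups is a number 29 percentage points lower from compound 1 to compound 3 (beyond the scatter), and compound 1 thus stays clear of both compounds that carry a nitrogen on that carbonyl, even though the branched alkyl group is present again in compound 3. What the shift of the branched chain from the carbonyl carbon to the nitrogen does at the receptor cannot be explained, as nothing available here accounts for this result.

As far as these compounds go, whether any group on this nitrogen can lift the number remains open, whether a longer chain such as n-butyl, a cyclohexyl ring, a benzyl group or a second methyl on the same nitrogen. Equally open is what on the carbonyl carbon carries the number of compound 1, since the shown compounds do not say how an ethoxy group, a methyl or a longer unbranched chain would read there.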